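The source may hold more compounds than are shown below. What is called first, only, known or untested is meant among the compounds shown, and "the series" means these compounds.

Of the compounds shown here, three share one core and have been tested in a functional assay on HCT-116 cells (Homo sapiens) for cytotoxicity, read by MTT assay, with a stated time of 2 days, tested at 10 uM; a lower number here means less inhibition, a higher number more inhibition at the concentration tested (going by the name of the read-out). Compound 1 `CCCCCNc1nc(NCc2ccco2)c2cc(F)ccc2n1` gives 94.2%, and compound 2 `CCCCNc1nc(NCc2ccco2)c2cc(F)ccc2n1` gives 87.8%; the step of a number 6.4 percentage points lower from compound 1 to compound 2 (within the scatter) is within the scatter. Compound 3 `COc1ccc(Nc2nc(NCc3ccco3)c3cc(F)ccc3n2)cc1` gives 74%, the lowest of the three numbers: the step of a number 20.2 percentage points lower from compound 1 to compound 3 (beyond the scatter) and the step of a number 13.8 percentage points lower from compound 2 to compound 3 (beyond the scatter) both lie beyond the scatter, so putting a 4-methoxyphenyl in place of a pentyl or butyl chain on that ring nitrogen went with modestly less inhibition.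

Compound 4 `CCN(CC)CCNc1nc(NCc2ccco2)c2cc(F)ccc2n1` is not yet measured. It differs from compound 3 in one place: 2-(diethylamino)ethyl in place of 4-methoxyphenyl on a nitrogen on an aromatic ring. This is a move back from an aromatic ring to a chain on the same nitrogen, the direction in which the steps from compound 1 and compound 2 to compound 3 ran in reverse. Among the compounds with values here, no measured step involves the 2-(diethylamino)ethyl chain itself, so the size is uncertain, but a modest rise in this assay is expected, roughly a number 11 percentage points higher from compound 3 to compound 4 (beyond the scatter). Compound 4 is therefore estimated at 85%, with a likely range from 65% to 97%.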

Compound 4, a percentage reported as inhibition, at one concentration (the size of the read-out at that concentration, not a potency): 26.4%
Beside the measured number, compound 4's estimate is 58.6 percentage points above it; the whole stated range lies above it.
By their numbers in this assay, from the lowest: compound 4; then compound 3; then compounds 2 and 1 (each within the scatter of the next).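

The earlier compounds shown here suggested that a chain on this ring nitrogen goes with more inhibition than 4-methoxyphenyl, but compound 4 shows that this does not hold for every chain: in this assay, 2-(diethylamino)ethyl in place of 4-methoxyphenyl gives a number 47.6 percentage points lower from compound 3 to compound 4 (beyond the scatter) and reverses the expected direction. Diethylamino on the chain also separates compound 4 from the plain chains, with a number 61.4 percentage points lower from compound 2 to compound 4 (beyond the scatter) and a number 67.8 percentage points lower from compound 1 to compound 4 (beyond the scatter), so what the chain carries matters here, not merely that a chain is present. The data shown offer no measured explanation for this drop.

As far as these compounds go, whether the drop follows the chain's nitrogen or the ethyl groups on it remains open. A dimethylamino group, a morpholine ring or a hydroxyl group at the same chain end would help separate these possibilities.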